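The source may hold more compounds than are shown below. What is called first, only, known or untested is meant among the compounds shown, and "the series" means these compounds.

Measured compounds:
compound 1 `COc1ccc(/C(=C(/CCCl)c2ccccc2)c2ccccc2)cc1` — in a functional assay on MDA-MB-231 cells (Homo sapiens) for cytotoxicity, read by MTT assay, with a stated time of 72 h (a higher number here means a weaker inhibitor, a lower number a stronger inhibitor), compound 1 gives > 50000 nM
compound 2 `COc1ccc(/C(=C(/CCN)c2ccccc2)c2ccccc2)cc1` — in this assay compound 2 gives 11400 nM

The value for compound 1 is a limit of the assay, not a number (the limit of > 50000 nM in this assay, at which 1 of the 2 values shown sits). For the measured compounds named here, compound 2 therefore holds the only number so far in this assay.

Compound 3 `CCOC(=O)C(=O)NCC/C(=C(\c1ccccc1)c1ccc(OC)cc1)c1ccccc1` differs from compound 2 by (ethoxycarbonyl)carbonyl in place of hydrogen on an amine nitrogen. Going by the values given here, the single measured step, an at least 4.3-fold lower number from compound 1 to compound 2 (0.64 log units; beyond the scatter), concerns the same chain position: chloro to amino, with its size bounded only by the limit of compound 1 (the limit of > 50000 nM in this assay, at which 1 of the 2 values shown sits). Among the compounds with values here, no measured step caps the amine nitrogen itself, so the new step cannot be read from a precedent of the same kind; the one step that exists links the free amino group with the lower number.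

Compound 3 is expected to give about 18000 nM, with a range from 5000 nM to 50000 nM. The estimated step is a 1.6-fold higher number from compound 2 to compound 3 (0.20 log units; within the scatter), and a result reported only as a limit is a real possibility.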

Compound 3, half-maximal inhibitory concentration: > 50000 nM
Compound 3 was reported as a limit (the forecaster's own chance of this, stated with the estimate: 30%); middle value at least 2.7-fold (0.44 log units) away from the limit.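

In this assay, (ethoxycarbonyl)carbonyl on the amine nitrogen gives an at least 4.3-fold higher number from compound 2 to compound 3 (0.64 log units; beyond the scatter), so the free amino group of compound 2 remains the only chain end shown that yields a number. The value of compound 3, > 50000 nM, is a limit of the assay and not a number. Compound 1 and compound 3 therefore cannot be ordered against each other, and the step between them cannot be read: the limit of > 50000 nM in this assay, at which 2 of the 3 values shown sit.

From the compounds shown here alone, how far compound 3 actually lies beyond compound 2 remains open, as does whether a smaller group on the same nitrogen, such as acetyl or methyl, would still give a number. Also open, going by these compounds, is whether the amino group keeps its number on a longer chain or as a dimethylamine.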